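A few compounds are considered here, and "the series" means these few. Any claim that something is new, unique, unknown or untested is made for them only; others in the source may bear on it.

Measured so far in a functional assay on SK-BR-3 cells (Homo sapiens) for cytotoxicity, read by MTT assay, with a stated time of 72 h; a lower number here means a stronger inhibitor, a higher number a weaker inhibitor:
Compound 1 `O=C(NC/C=C\Cn1ccc(=O)[nH]c1=O)c1ccccc1` gives > 100000 nM, which is a limit of the assay rather than a number.
Compound 2 `O=C(NC/C=C\Cn1cc(F)c(=O)[nH]c1=O)c1ccccc1` gives > 100000 nM, again a limit of the assay.
Compound 3 `Nc1ccn(C/C=C\CNC(=O)c2ccccc2)c(=O)n1` gives 72000 nM.

From compound 1 to compound 2 the change is fluoro in place of hydrogen on an aromatic carbon and the step is a step that the two limits leave unreadable from compound 1 to compound 2; the size cannot be read because of the limit of > 100000 nM in this assay, at which 2 of the 3 values shown sit. How the core of compound 3 differs from that of compound 1 is not broken down here. Compound 4 `Nc1ccn(C/C=C\CNC(=O)c2ccc(F)cc2)c(=O)n1` has not yet been measured. It differs from compound 3 by fluoro in place of hydrogen on an aromatic carbon, the same kind of change as from compound 1 to compound 2, but in a different setting: in compound 4 the fluoro sits on a six-membered aromatic ring of carbon only, para to a large group, whereas in compound 2 it sits on a six-membered aromatic ring with 2 nitrogen, ortho to a group of 1 heavy atom and two atoms from the ring nitrogen. The earlier step gives no readable size, so the expectation for compound 4 rests on compound 3 alone, with 72000 nM as the anchor; the expected step is a 1.0-fold lower number from compound 3 to compound 4 (0.01 log units; within the scatter). Compound 4 is therefore estimated at 70000 nM, likely between 25000 nM and 200000 nM.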

Compound 4, half-maximal inhibitory concentration: > 100000 nM
Compound 4: a limit, no number; the forecaster's own chance of this, stated with the estimate: 35%; at least 1.4-fold (0.15 log units) between middle value and limit.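

In this assay, going from phenyl to 4-fluorophenyl gives an at least 1.3-fold higher number from compound 3 to compound 4 (0.14 log units; that floor lies within the scatter), so this result cannot be told apart from no change at all. Going by these compounds, compound 4 gives > 100000 nM, which is a limit of the assay and not a number, so the fluoro brought no stronger number on this core, while the true size of the step stays unknown. The same kind of change on the other core, from compound 1 to compound 2, cannot be read either, so nothing here shows whether the effect of fluoro carries from one core to the other, because the values stop at a limit: the limit of > 100000 nM in this assay, at which 3 of the 4 values shown sit.

The compounds shown leave open whether a chloro or methoxy group, or an amine, in place of the fluoro on the phenyl ring would give a number clear of that limit. They also leave open whether a longer chain joining the two halves of the molecule would do so.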